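Working notes: from compound 3 to compound 4

A few compounds are considered here, and "the series" means these few. Any claim that something is new, unique, unknown or untested is made for them only; others in the source may bear on it.

- compound 1 `CC(/C=C/C1=CCCCC1(C)C)=C\C=C\C(C)=C\COC(=O)c1ccccc1O`: 150000 nM
- compound 2 `COc1cc(NC(C)=O)cc(C(=O)OC/C=C(C)/C=C/C=C(C)/C=C/C2=CCCCC2(C)C)c1O`: < 10000 nM
- compound 3 `COc1ccc(O)c(C(=O)OC/C=C(C)/C=C/C=C(C)/C=C/C2=CCCCC2(C)C)c1`: 570000 nM

In a toxicity assay on cells (Fibroblast, Homo sapiens) for cytotoxicity (a higher number here means a weaker inhibitor, a lower number a stronger inhibitor), compound 3 at 570000 nM is the highest of the two exact numbers, and compound 1 is nearest at 150000 nM. The entry for compound 2 is a limit and not a number.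

Compound 4 `CC(/C=C/C1=CCCCC1(C)C)=C\C=C\C(C)=C\COC(=O)c1cccc(O)c1O` carries 2,3-dihydroxyphenyl in place of 2-hydroxy-5-methoxyphenyl on a carbonyl carbon. For the measured compounds named here, the one measured step that bears on this change is a 3.8-fold higher number from compound 1 to compound 3 (0.58 log units; beyond the scatter), with methoxy in place of hydrogen on an aromatic carbon. Going by the values given here, compound 4 has no methoxy, so part of that modest step may be reversed, although no measured step covers the added hydroxyl. Compound 2 also carries a methoxy, and it goes against any general rise with that group.

A modest move to a lower number is expected in this assay, and the expected change is a 3.2-fold lower number from compound 3 to compound 4 (0.50 log units; beyond the scatter). For compound 4 the estimated value is 180000 nM, with an estimated range of 50000 nM to 500000 nM.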

Compound 4, half-maximal inhibitory concentration: < 10000 nM
Compound 4: no number, only a limit; the forecaster's own chance of this, stated with the estimate: 15%; middle value at least 18-fold (1.25 log units) from the limit.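

In this assay compound 4 gives < 10000 nM, which is a limit of the assay and not a number: the limit of < 10000 nM in this assay, at which 2 of the 4 values shown sit.

On the carbonyl carbon, 2,3-dihydroxyphenyl in place of 2-hydroxy-5-methoxyphenyl gives an at least 57-fold lower number from compound 3 to compound 4 (1.75 log units; beyond the scatter), and a single added hydroxy on the aromatic ring gives an at least 15-fold lower number from compound 1 to compound 4 (1.17 log units; beyond the scatter). For the compounds shown here, the only earlier step on this aromatic ring was modest and ran the other way, a 3.8-fold higher number from compound 1 to compound 3 (0.58 log units; beyond the scatter), so this ring can move the read-out much further, and towards lower numbers, than that step suggested.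

From the compounds shown here alone, the true size of both new steps stays open, as does any ranking of compound 2 against compound 4, since both entries are limits. Also open, going by these compounds, is whether an amine or a carboxylic acid in place of the added hydroxy would give a similar drop.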